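The compounds below may be only part of what the source reports. "The series", "measured", "known", "first", "only" and "open" are said of these compounds alone.

Measured compounds in an ADME assay on Vero cells (Chlorocebus sabaeus) for cytotoxicity, read by MTT assay, with a stated time of 72 h; on this read-out lower numbers stand for higher toxicity in this test and higher numbers for lower toxicity in this test:
compound 1 `O=C(c1ccccc1F)N1CCN(c2nc(=O)c3cc(C(F)(F)F)cc([N+](=O)[O-])c3s2)CC1` gives > 125000 nM, a limit of the test.
compound 2 `O=C(C1CC1)N1CCN(c2nc(=O)c3cc(C(F)(F)F)cc([N+](=O)[O-])c3s2)CC1` gives > 125000 nM, likewise a limit.

Compound 2 thus stands at the limit of > 125000 nM in this assay, at which 2 of the 2 values shown sit, in this assay. For the measured compounds named here, the only measured step, a step that the two limits leave unreadable from compound 1 to compound 2, is one the two limits leave unreadable, so its size says nothing about the next change. Compound 3 `CCC(C)C(=O)N1CCN(c2nc(=O)c3cc(C(F)(F)F)cc([N+](=O)[O-])c3s2)CC1` differs from compound 2 by sec-butyl in place of cyclopropyl on a carbonyl carbon. Going by the values given here, no measured step bears on this change with a readable size, and both values rest at the limit. Compound 3 is therefore expected to show no step beyond the scatter, a step that the limit leaves unreadable from compound 2 to compound 3, and most likely to be reported as a limit again. The estimate for compound 3 in this assay is 150000 nM, ranging from 60000 nM to 400000 nM.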

Compound 3, half-maximal cytotoxic concentration: > 125000 nM
Compound 3 was reported as a limit; the forecaster's own chance of this, stated with the estimate: 80%; the middle value does not contradict the limit.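

Compound 1, compound 2 and compound 3 all rest at a limit, so no step among them can be read: the limit of > 125000 nM in this assay, at which 3 of the 3 values shown sit.

As far as these compounds go, whether any group on the carbonyl carbon of the shared core would give a readable value remains open.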